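The source may hold more compounds than are shown below. What is called first, only, known or untested is meant among the compounds shown, and "the series" means these compounds.

Compound 3 `Cc1ccccc1C(=O)Nc1ccc(S(=O)(=O)NC2CCN(C(=O)OCCCN(C)C)CC2)c2ccccc12` is one of three compounds with a number in an in vitro functional assay on CHO/Galpha16 cells for antagonist activity at C-C chemokine receptor type 8 (Homo sapiens), read by FLIPR; a higher number here means a weaker inhibitor, a lower number a stronger inhibitor. Compound 1 `CCCC(=O)N1CCC(NS(=O)(=O)c2ccc(NC(=O)c3ccc(CC)cc3)c3ccccc23)CC1` gives 10.8 nM in this assay, compound 2 `CCCC(=O)N1CCC(NS(=O)(=O)c2ccc(NC(=O)c3cc(C)oc3C(F)(F)F)c3ccccc23)CC1` gives 46.9 nM, and compound 3 gives 9.8 nM. On these numbers compound 3 sits at the low end, but its gap to compound 1 is within the scatter; only against compound 2 does the gap stand beyond it.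

Compound 4 `Cc1ccccc1C(=O)Nc1ccc(S(=O)(=O)NC2CCN(C(=O)OCCCN3CC(C)OC(C)C3)CC2)c2ccccc12` differs from compound 3 by 2,6-dimethylmorpholin-4-yl in place of dimethylamino on a saturated chain carbon, three bonds along the chain from an oxygen next to a carbonyl group. Among the compounds with values here, the only measured step in the set, a 4.3-fold higher number from compound 1 to compound 2 (0.64 log units; beyond the scatter), is a change on a carbonyl carbon and not on the chain where compound 3 and compound 4 differ; no measured step replaces the amine at the end of that chain. Within the data shown here, there is thus no direct precedent, and the weight of the evidence is that the carbamate chain of compound 3 carries a number within the scatter of compound 1, which has a plain butanoyl group there instead.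

For compound 4 the expected step is therefore a 1.2-fold higher number from compound 3 to compound 4 (0.09 log units; within the scatter), not beyond the scatter in either direction. Compound 4 is estimated at 12 nM in this assay, with a range from 4 nM to 36 nM.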

Compound 4, half-maximal inhibitory concentration: 19.6 nM
Beside the measured number, compound 4's estimate is 1.6-fold (0.21 log units) below it, and the stated range covers the measured number.
By their numbers in this assay, from the lowest: compounds 3, 1 and 4 (each within the scatter of the next); then compound 2.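

In this assay, the end of the 3-(dimethylamino)propyl chain on the carbamate accepts a substantial change: a 2.0-fold higher number from compound 3 to compound 4 (0.30 log units; within the scatter) when dimethylamino gives way to 2,6-dimethylmorpholin-4-yl. Within the data shown here, the entering group brings a six-membered non-aromatic ring, a second hydrogen-bond acceptor and more heavy atoms, yet the step stays within the scatter, so this is the first direct reading at this position and it shows no clear penalty or gain from the swap. This single pair supports no rule for the chain end in general, and nothing available here bears on why the number moves so little.

Still open, going by these compounds, is how much of the result belongs to the ring itself and how much to its two methyl groups, which a plain morpholine or a piperidine at the chain end would help to separate. Also open, on these data alone, is whether the position stays this permissive with a carboxylic acid or a hydroxyl group at the chain end in place of the amine, or with a shorter chain carrying the same 2,6-dimethylmorpholin-4-yl.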